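Fluoro for butyl on the core of compound 1

This account rests on a few compounds, and the source may have more. Where it says the series, first, only, none or still open, it means among the compounds named here.

Compound 1 `CCCCc1ccc2ncc(-c3nn[nH]n3)cc2c1` has been tested in a functional assay on the whole organism (strain Sprague-Dawley) for inhibition, with Rattus norvegicus as the target; on this read-out higher numbers stand for an effect only at larger amounts of compound and lower numbers for an effect already at smaller amounts. In this assay compound 1 gives > 25 mg/kg, which is a limit of the assay and not a number (the limit of > 25 mg/kg in this assay, at which 1 of the 3 values shown sits). Two further compounds on other cores have numbers: compound 2 `O=c1c(-c2nn[nH]n2)c[nH]c2c(Cl)ccc(Cl)c12` gives 0.312 mg/kg, and compound 3 `CCc1cccc2cc(-c3nn[nH]n3)cnc12` gives 5 mg/kg. For the measured compounds named here, no single-change step between any two measured compounds exists in this set, so the values of compound 2 and compound 3 are noted only as they stand.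

Compound 4 `Fc1ccc2ncc(-c3nn[nH]n3)cc2c1` is the next compound to be measured. It differs from compound 1 in one place: fluoro in place of butyl on an aromatic carbon.

Going by the values given here, since compound 1 offers only a limit, no measured step fixes the direction of this change. The step from compound 1 to compound 4 is expected to be a number no higher from compound 1 to compound 4 (the limit leaves the size open), which may be no more than the scatter. For compound 4 the estimate in this assay is 25 mg/kg, with a range from 6 mg/kg to 50 mg/kg.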

Compound 4, minimum effective dose: 50 mg/kg
Beside the measured number, compound 4's estimate is 2.0-fold (0.30 log units) below it; low and high end bracket the measured number.
By their numbers in this assay, from the lowest: compound 2; then compound 3; then compound 4.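

No step from compound 1 to compound 4 can be read, because compound 1 stands at a limit of the assay and not at a number: the limit of > 25 mg/kg in this assay, at which 1 of the 4 values shown sits.

The compounds shown leave open both the direction and the size of the change on swapping butyl for fluoro on this core.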